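Swapping a fluorine for a hydroxyl on the sulfonyl ring

The source may report more compounds than this note shows. Statements on the series, on what has been measured and on what is new or still open speak of the compounds shown alone.

Compound 1 `O=S(=O)(Nc1ccc(-c2nc3ccccc3o2)cc1)c1cccc(O)c1` and compound 2 `O=S(=O)(Nc1ccc(-c2nc3ccccc3o2)cc1)c1ccccc1F` share one core and differ only in the ring on the sulfonyl sulfur. In an assay on isolated protein for inhibition of malate dehydrogenase, mitochondrial (Sus scrofa), with stated times of 45 min and 30 min (a higher number here means a weaker inhibitor, a lower number a stronger inhibitor), compound 1 gives > 63000 nM, which is a limit of the assay rather than a number. In this assay compound 2 likewise gives > 63000 nM, again a limit. The step that the two limits leave unreadable from compound 1 to compound 2 therefore cannot be read, and the limit of > 63000 nM in this assay, at which 2 of the 2 values shown sit, describes where both values sit.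

Compound 3 `O=S(=O)(Nc1ccc(-c2nc3ccccc3o2)cc1)c1ccc(O)cc1` is the next variation: 4-hydroxyphenyl in place of 2-fluorophenyl on a sulfonyl sulfur. For the measured compounds named here, the only measured step with a comparable change is the unreadable one from compound 1 to compound 2, so the data give no direction beyond the scatter. Compound 3 is expected to remain around 80000 nM, within 30000 nM to 250000 nM, most likely reported again as a limit. The expected step that the limit leaves unreadable from compound 2 to compound 3 is thus essentially none.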

Compound 3, half-maximal inhibitory concentration: > 63000 nM
Compound 3: no number, only a limit (the forecaster's own chance of this, stated with the estimate: 80%); the middle value is on the limit's open side.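

In this assay compound 3 gives > 63000 nM, which is a limit and not a number. The steps from compound 1 and from compound 2 to compound 3 therefore cannot be read. Still open is how strongly any of these compounds inhibits, and whether the ring on the sulfonyl sulfur matters, given where the values sit: the limit of > 63000 nM in this assay, at which 3 of the 3 values shown sit.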